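This account rests on a few compounds, and the source may have more. Where it says the series, first, only, none or still open, it means among the compounds named here.

Of the compounds shown here, three have been measured in an assay on isolated protein for displacement of a labelled ligand from metabotropic glutamate receptor 5 (Homo sapiens), with a stated time of 60 min, tested at 1 uM; on this read-out higher numbers stand for more inhibition at the one concentration tested (going by the name of the read-out) and lower numbers for less inhibition. Compound 1 `CC1CCN(c2c(S(=O)(=O)c3ccc(Cl)cc3)cnc3ccc(F)cc23)CC1` gives 80%, and compound 2 `CC1CCN(c2c(S(=O)(=O)c3ccc(C#N)cc3)cnc3cc(F)ccc23)CC1` gives 83%. Compound 3 `COc1ccc2ncc(S(=O)(=O)c3ccc(OC)c(OC)c3)c(N3CCC(C)CC3)c2c1` gives -3% in this assay, which is the lowest of the three numbers; its gap to compound 1 and its gap to compound 2 both lie beyond the usual scatter of repeated measurements, so the number for compound 3 in this assay is lower than those of the other two at this concentration.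

Compound 4 `COc1ccc2ncc(S(=O)(=O)c3ccc(F)cc3)c(N3CCC(C)CC3)c2c1` has not yet been measured. It shares the core of compound 3 and differs from it in a single place: 4-fluorophenyl in place of 3,4-dimethoxyphenyl on a sulfonyl sulfur. Within the data shown here, no pair of measured compounds differing in only one place is available, so the size of this step cannot be read off directly. What the numbers do show is that the two compounds with the higher numbers, compound 1 with 80% and compound 2 with 83%, both lack the 3,4-dimethoxyphenyl that compound 3 carries and that the change removes, and both carry a single small substituent on the aromatic ring attached to the sulfonyl sulfur, as the 4-fluorophenyl of compound 4 does.

Compound 4 is therefore expected to give a much higher number than compound 3, with an estimated 50% and a likely range from 10% to 90%. The implied step a number 53 percentage points higher from compound 3 to compound 4 (beyond the scatter) in this assay is expected to lie beyond the scatter, though the estimate is uncertain.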

Compound 4, a percentage reported as inhibition, at one concentration (the size of the read-out at that concentration, not a potency): 27%
Compound 4: middle estimate off by 23 percentage points, on the high side, within the range that was stated.
By their numbers in this assay, from the lowest: compound 3; then compound 4; then compounds 1 and 2 (each within the scatter of the next).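

Among these compounds, this is the first pair of compounds that differ in one place only, so it isolates the group on the sulfonyl sulfur: in this assay, replacing 3,4-dimethoxyphenyl with 4-fluorophenyl gives a number 30 percentage points higher from compound 3 to compound 4 (beyond the scatter), a modest step beyond the scatter. The change removes 10 heavy atoms and 2 hydrogen-bond acceptors and brings in 7 heavy atoms and 0 hydrogen-bond acceptors, but this one pair cannot show which of these differences, if any, accounts for the step. Nothing measured here explains the rise in the number.

Steps from compound 4 to compound 1 or compound 2 cannot be read, as these compounds differ in more than one place, so the separate contributions of the sulfonyl group's aromatic substituent and the other substituents on the core remain unresolved. From the compounds shown here alone, it also remains open how this position would respond to an unsubstituted phenyl or a 4-methoxyphenyl on the same core, the latter of which would help separate the effect of keeping one methoxy group from that of introducing fluorine.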